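Removing the amino link from compound 2: a forecast

A few compounds are considered here, and "the series" means these few. Any claim that something is new, unique, unknown or untested is made for them only; others in the source may bear on it.

Compound 1 `COc1cc(Cl)cc(-c2nn(-c3cccc(NC(=O)c4ccc(Cl)c(Cl)c4)c3)cc2-c2ccncc2)c1` and compound 2 `COc1cc(Cl)cc(-c2nn(-c3cccc(NC(=O)Nc4cccc(C(F)(F)F)c4)c3)cc2-c2ccncc2)c1` share one core and differ on the carbonyl carbon. In a functional assay on K562 cells (Homo sapiens) for inhibition, read by sulforhodamine B assay, with a stated time of 48 h, tested at 10 uM (on this read-out lower numbers stand for a stronger effect and higher numbers for a weaker effect at the one concentration tested), compound 1 gives 46.4%, while compound 2 gives 7.61%; the step of a number 38.8 percentage points lower from compound 1 to compound 2 (beyond the scatter) makes compound 2 the lowest of the two numbers, the stronger of the pair. Compound 3 `COc1cc(Cl)cc(-c2nn(-c3cccc(NC(=O)c4cccc(C(F)(F)F)c4)c3)cc2-c2ccncc2)c1` has not yet been measured; it differs from compound 2 by 3-(trifluoromethyl)phenyl in place of (3-(trifluoromethyl)phenyl)amino on a carbonyl carbon. Going by the values given here, the only measured step, from compound 1 to compound 2, swapped the aryl part and the amino link at once, so it bears on this change only indirectly: compound 3 keeps the aryl part of compound 2 but the direct aryl-carbonyl arrangement of compound 1. The writer therefore expects a rise, a number 19.4 percentage points higher from compound 2 to compound 3 (beyond the scatter), toward the middle ground. For compound 3 the estimated value is 27%, within 5% to 55%.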

Compound 3, a percentage reported as activity, at one concentration (the size of the read-out at that concentration, not a potency): 26%
Estimate against measurement, compound 3: 1 percentage points above; the measured number falls inside the stated range.
By their numbers in this assay, from the lowest: compound 2; then compound 3; then compound 1.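

With the 3-(trifluoromethyl)phenyl group held fixed, compound 3 isolates the amino link on the carbonyl carbon: in this assay, losing that link alone gives a number 18.4 percentage points higher from compound 2 to compound 3 (beyond the scatter). Going by these compounds alone, with the direct aryl-carbonyl arrangement held fixed, changing only the aryl group gives a number 20.4 percentage points lower from compound 1 to compound 3 (beyond the scatter), so the single large step between compound 1 and compound 2 now resolves into two separate changes, each beyond the scatter. No measurement shown here explains either step.

From the compounds shown here alone, it remains open whether the number follows the amino link itself or its hydrogen, which a methylamino or a methylene link on the same carbonyl carbon would test. Going by these compounds, it is also open whether a (3,4-dichlorophenyl)amino group would show the same lowering that the amino link shows with 3-(trifluoromethyl)phenyl.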